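The source may report more compounds than this note shows. Statements on the series, on what has been measured and on what is new or still open speak of the compounds shown alone.

Measured in a functional assay on A549 cells (Homo sapiens) for cytotoxicity, read by sulforhodamine B assay, with a stated time of 48 h; a lower number here means a stronger inhibitor, a higher number a weaker inhibitor:
compound 1 `CO[C@@H]1CC=C2NN(c3c[nH]c4ccccc34)C(=O)CC[C@]2(c2ccccc2)O1`: 1110 nM
compound 2 `CO[C@@H]1CC=C2N(c3ccc(C)cc3)C(=O)C[C@]2(c2ccccc2)O1`: 3920 nM
compound 3 `CO[C@@H]1CC=C2N(c3ccc([N+](=O)[O-])cc3)C(=O)C[C@]2(c2ccccc2)O1`: 7150 nM

Compound 3 gives the highest of the three numbers. Among the compounds with values here, the one single-point step in the set is a 1.8-fold higher number from compound 2 to compound 3 (0.26 log units; within the scatter) and lies within the scatter. Within the data shown here, its gap to compound 1 is beyond the scatter, but those two structures differ in more than one place, so no single step is defined between them.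

Compound 4 `CO[C@@H]1CC=C2N(c3ccccn3)C(=O)C[C@]2(c2ccccc2)O1` carries pyridin-2-yl in place of 4-nitrophenyl on an amide-type nitrogen in a ring. Among the measured compounds shown here, the only single-point step in the set exchanges one substituent on the aryl ring and stays within the scatter; no measured step swaps the ring itself. With nothing to support a larger shift, the expected step for compound 4 is a 1.4-fold lower number from compound 3 to compound 4 (0.16 log units; within the scatter). Compound 4 is therefore estimated at 5000 nM, range 2000 nM to 15000 nM.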

Compound 4, half-maximal inhibitory concentration: 6110 nM
Beside the measured number, compound 4's estimate is 1.2-fold (0.09 log units) below it; the range from low to high includes it.
By their numbers in this assay, from the lowest: compound 1; then compounds 2, 4 and 3 (each within the scatter of the next).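

Exchanging the aryl ring itself on the amide-type nitrogen, not just its substituent, gives a 1.2-fold lower number from compound 3 to compound 4 (0.07 log units; within the scatter) and a 1.6-fold higher number from compound 2 to compound 4 (0.19 log units; within the scatter) in this assay. So in this series, pyridin-2-yl, with its ring nitrogen and no further substituent, cannot be told apart from 4-nitrophenyl or 4-methylphenyl at this position. No supporting data bear on why these three groups read alike.

On these data alone, whether a saturated amine, a carboxylic acid or a longer chain on this nitrogen would move the number beyond the scatter remains open. As far as these compounds go, the other pyridinyl isomers are equally open.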